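An Octyl Chain Replaces the Silyl Alkyne

The source may hold more compounds than are shown below. What is called first, only, known or untested is meant among the compounds shown, and "the series" means these compounds.

Measured compounds:
compound 1, `CC(=O)Nc1nc(-c2cccc(NS(=O)(=O)c3ccc(C#CC4CCCCC4)cc3)c2)cs1`, 52.3%
compound 2, `CC(=O)Nc1nc(-c2cccc(NS(=O)(=O)c3ccc(C#C[Si](C)(C)C)cc3)c2)cs1`, 94.3%

Among the measured compounds shown here, only two compounds have so far been tested in a functional assay on A-375 cells (Homo sapiens) for antiproliferative activity, read by trypan blue exclusion, with a stated time of 48 h, tested at 1 uM; a lower number here means a stronger effect, a higher number a weaker effect of the compound at the concentration tested. Compound 2 stands highest of the two numbers; its nearest neighbour is compound 1, and the step of a number 42 percentage points higher from compound 1 to compound 2 (beyond the scatter) lies beyond the scatter. Compound 3, `CCCCCCCCc1ccc(S(=O)(=O)Nc2cccc(-c3csc(NC(C)=O)n3)c2)cc1`, departs from compound 2 by a group of 8 heavy atoms (8 carbon; no ring) in place of a group of 6 heavy atoms (5 carbon, 1 silicon; no ring), on an aromatic carbon. For the measured compounds named here, no measured step covers the octyl group itself, so the one step available, a number 42 percentage points higher from compound 1 to compound 2 (beyond the scatter), bears on the change only indirectly: it shows that the group on this aromatic carbon can shift the read-out greatly, and that the silyl alkyne of compound 2 gave the weaker effect. Compound 3 is therefore expected to move back toward a stronger effect, by a step of a number 29.3 percentage points lower from compound 2 to compound 3 (beyond the scatter), though with wide uncertainty. For compound 3 the estimate is 65%, within a range of 40% to 95%.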

Compound 3, a percentage reported as activity, at one concentration (the size of the read-out at that concentration, not a potency): 34.8%
Compound 3: the middle estimate sits 30.2 percentage points above what was measured; the measured number lies below the stated range.
By their numbers in this assay, from the lowest: compound 3; then compound 1; then compound 2.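

In this assay, the place on the aromatic carbon para to a large group does not need a triple bond for a strong effect: octyl, which has neither a triple bond nor a ring, gives the lowest number of the three compounds. Against the silyl alkyne the change is large, a number 59.5 percentage points lower from compound 2 to compound 3 (beyond the scatter), and it also improves on the cyclohexyl alkyne by a modest step, a number 17.5 percentage points lower from compound 1 to compound 3 (beyond the scatter), so the open octyl chain outperforms both alkynes at this position. No evidence on the compounds accounts for either step.

The compounds shown leave open whether a shorter chain such as butyl or a longer chain such as dodecyl would lower the number further. They also leave open how a saturated 2-cyclohexylethyl group or an amine on the chain would compare with octyl.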